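This account rests on a few compounds, and the source may have more. Where it says the series, first, only, none or still open, it means among the compounds named here.

Working notes on a small thiourea series, all sharing the core of compound 1 `FC(F)(F)c1cccc(NC(=S)Nc2cccc(Br)c2)c1` with its trifluoromethyl group. In an ADME assay on Vero 76 cells (Chlorocebus sabaeus) for cytotoxicity, read by crystal violet staining, with a stated time of 96 h (a lower number here means that less compound is tolerated, a higher number that more compound is tolerated), compound 1 gives 14000 nM, the second highest of the three numbers at hand. Compound 2 `O=[N+]([O-])c1ccc(NC(=S)Nc2cccc(C(F)(F)F)c2)cc1` gives 10000 nM and compound 3 `Fc1ccc(NC(=S)Nc2cccc(C(F)(F)F)c2)cc1Cl` gives 20000 nM; both gaps to compound 1 fall within the scatter, so the three stand together. Compound 4 `CSCCCNC(=S)Nc1cccc(C(F)(F)F)c1` is not yet measured; it differs from compound 1 by 3-(methylsulfanyl)propyl in place of 3-bromophenyl on an amide-type nitrogen. Going by the values given here, no single-change step between measured compounds exists to calibrate this move. Among the compounds with values here, a modest shift toward a higher number is expected, a 1.8-fold higher number from compound 1 to compound 4 (0.25 log units; within the scatter), though the three values known so far leave a result within the scatter equally plausible. Compound 4 is estimated at 25000 nM, range 8000 nM to 70000 nM.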

Compound 4, half-maximal cytotoxic concentration: > 100000 nM
Compound 4: a limit, no number (the forecaster's own chance of this, stated with the estimate: 15%); middle value at least 4.0-fold (0.60 log units) from the limit.
By their numbers in this assay, from the lowest: compounds 2, 1 and 3 (each within the scatter of the next). At a limit, above all of these: compound 4.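

In this assay compound 4 gives > 100000 nM, which is a limit of the assay and not a number. Placing 3-(methylsulfanyl)propyl in place of 3-bromophenyl on the amide-type nitrogen gives an at least 7.1-fold higher number from compound 1 to compound 4 (0.85 log units; beyond the scatter) and is the first change here to lie beyond the scatter, whereas compounds 1, 2 and 3 stand together. This position therefore can move the tolerated concentration, and the true size of the step remains unbounded on its upper side.

These compounds cannot separate the loss of the aromatic ring from the entry of the sulfur-bearing chain. A plain butyl chain, or a propyl chain ending in an amine, would leave that question open no longer.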